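The source may report more compounds than this note shows. Statements on the series, on what has been measured and on what is new or still open speak of the compounds shown alone.

Compound 1 `CCCC(Oc1ccc(-n2cccn2)cc1)c1ccc(C(=O)NCCC(=O)O)cc1` gives 4100 nM in an assay on cells for displacement of a labelled ligand from Glucagon receptor (Homo sapiens), in the presence of a further agent that is not named here; on this read-out lower numbers stand for stronger inhibition and higher numbers for weaker inhibition. Compound 2 `CCCC(Oc1ccc(-n2cc(F)cn2)cc1)c1ccc(C(=O)NCCC(=O)O)cc1` gives 1700 nM. Compound 3 `CCCC(Oc1ccc(-n2cc(C)cn2)cc1)c1ccc(C(=O)NCCC(=O)O)cc1` gives 1900 nM.

Among these three numbers compound 3 stands second highest, sitting close to compound 2 and clearly apart from compound 1 a 2.2-fold lower number from compound 1 to compound 3 (0.33 log units; beyond the scatter). Compound 4 `CCCC(Oc1ccc(-n2cc(Cl)cn2)cc1)c1ccc(C(=O)NCCC(=O)O)cc1` differs from compound 3 by chloro in place of methyl on an aromatic carbon. Going by the values given here, two measured steps bear on this change: fluoro in place of hydrogen at the same carbon gave a modest gain a 2.4-fold lower number from compound 1 to compound 2 (0.38 log units; beyond the scatter), while methyl in place of fluoro showed nothing beyond the scatter a 1.1-fold higher number from compound 2 to compound 3 (0.05 log units; within the scatter). A chloro at that carbon is therefore expected to behave much like fluoro or methyl, giving a step of a 1.3-fold lower number from compound 3 to compound 4 (0.10 log units; within the scatter) that is expected to remain within the scatter. Compound 4 is estimated at 1500 nM, with a range from 700 nM to 3500 nM.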

Compound 4, inhibition constant: 1100 nM
Compound 4: the middle estimate sits 1.4-fold (0.13 log units) above what was measured; the range from low to high includes it.
By their numbers in this assay, from the lowest: compounds 4, 2 and 3 (each within the scatter of the next); then compound 1.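

With chloro, all three groups shown at this aromatic carbon of the five-membered ring give a lower number than hydrogen, and the step for chloro is beyond the scatter (a 3.7-fold lower number from compound 1 to compound 4 (0.57 log units; beyond the scatter)). The three groups cannot be ranked against one another, since chloro stays within the scatter of both methyl (a 1.7-fold lower number from compound 3 to compound 4 (0.24 log units; within the scatter)) and fluoro (a 1.5-fold lower number from compound 2 to compound 4 (0.19 log units; within the scatter)). Nothing measured here explains why these groups act alike at this carbon.

Still open, on these data alone, is whether a nitrile, an amine or a trifluoromethyl group at this carbon would lower the number further.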